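The source may report more compounds than this note shows. Statements on the series, on what has been measured and on what is new or still open speak of the compounds shown alone.

Working notes on the series

Compound 1 `O=C(Nc1ccc(Oc2ccnc3[nH]ccc23)c(F)c1)c1nn(-c2ccccc2)ccc1=O` and compound 2 `O=C(Nc1ccc(Oc2ccnc3[nH]ccc23)c(F)c1)c1nn(-c2ccc(Br)cc2F)ccc1=O` share one core; compound 3 `Cn1ccc2c(Oc3ccc(NC(=O)c4nn(-c5ccccc5)ccc4=O)cc3)ccnc21` and compound 4 `Cn1ccc2c(Oc3ccc(NC(=O)c4nn(-c5ccc(Br)cc5F)ccc4=O)cc3)ccnc21` share another. The difference between the two cores is not broken down here.

In a functional assay on HepG2 cells (Homo sapiens) for cytotoxicity, read by MTT assay, with a stated time of 72 h (on this read-out lower numbers stand for stronger inhibition and higher numbers for weaker inhibition), compound 1 gives 24900 nM. Compound 2 carries the change 4-bromo-2-fluorophenyl in place of phenyl on an aromatic nitrogen and gives 56500 nM in this assay, so that a 2.3-fold higher number from compound 1 to compound 2 (0.36 log units; beyond the scatter).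

Compound 3 gives 56200 nM in this assay, which is within the scatter of compound 2 and a higher number than compound 1.

Compound 4 carries the same kind of change on the second core, (4-bromo-2-fluorophenyl in place of phenyl on an aromatic nitrogen). Among the measured compounds shown here, the only precedent for this change is the step between compound 1 and compound 2, where the number rose modestly; the same direction is expected here, since no other pair shows the change on the second core. Compound 4 is therefore expected to give 110000 nM in this assay, estimated between 50000 nM and 250000 nM, which would mean an expected step of a 2.0-fold higher number from compound 3 to compound 4 (0.29 log units; within the scatter). Whether compound 4 repeats the step or departs from it awaits the measurement.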

Compound 4, half-maximal inhibitory concentration: 31200 nM
For compound 4 the middle estimate is 3.5-fold (0.55 log units) above the measured one, outside the stated range (below it).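

In this assay the change to 4-bromo-2-fluorophenyl in place of phenyl gives a 1.8-fold lower number from compound 3 to compound 4 (0.26 log units; within the scatter), so on these two cores it does not behave as one fixed step that can be carried from the core of compound 1 to the core of compound 3: the same change on two cores in this assay, a 2.3-fold higher number (0.36 log units; beyond the scatter) from compound 1 to compound 2 and a 1.8-fold lower number (0.26 log units; within the scatter) from compound 3 to compound 4, 4.1-fold (0.61 log units) apart, beyond the scatter of two such steps. On its own the new step lies within the scatter, so a reversal of direction is not shown; only the gap between the two steps lies beyond the scatter. Two pairs give no cause for that gap, and with bromine and fluorine entering together, neither atom can be credited with any part of it.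

Open, from the compounds shown here alone, is how a phenyl carrying only the bromine or only the fluorine, or one carrying an amine, would behave on either core. Also open, going by these compounds, is which of the differences between the two cores goes with the gap.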